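The compounds below may be only part of what the source reports. "The series", "measured", "known", "first", "only" and "open" are said of these compounds alone.

Three compounds that share one core were tested in a functional assay on MDA-MB-231 cells (Homo sapiens) for antiproliferative activity, read by MTT assay, with a stated time of 24 h; on this read-out lower numbers stand for stronger inhibition and higher numbers for weaker inhibition. Compound 1 `COc1ccc(-c2cc(/C=C/C(=O)c3ccc(Cl)cc3)nc3cc(-c4ccccc4)nn23)cc1OC` gives 17100 nM. Compound 2 `COc1ccc(-c2cc(/C=C/C(=O)c3ccc(C)cc3)nc3cc(-c4ccccc4)nn23)cc1OC`, with methyl in place of chloro on an aromatic carbon, gives 19800 nM, a change of a 1.2-fold higher number from compound 1 to compound 2 (0.06 log units; within the scatter). Compound 3 `COc1ccc(-c2cc(C(=O)/C=C/c3ccccc3)nc3cc(-c4ccccc4)nn23)cc1OC`, with (2-phenylethenyl)carbonyl in place of 2-((4-chlorophenyl)carbonyl)ethenyl on an aromatic carbon, gives 23300 nM; the corresponding steps are a 1.4-fold higher number from compound 1 to compound 3 (0.13 log units; within the scatter) and a 1.2-fold higher number from compound 2 to compound 3 (0.07 log units; within the scatter). Compound 3 thus holds the highest of the three numbers, yet every step leading to it lies within the scatter, so the three compounds cannot be told apart on these numbers.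

Compound 4 `COc1cc(-c2cc(C(=O)/C=C/c3ccccc3)nc3cc(-c4ccccc4)nn23)cc(OC)c1OC` has not yet been measured. It differs from compound 3 by methoxy in place of hydrogen on an aromatic carbon, which, seen one bond further out, turns 3,4-dimethoxyphenyl into 3,4,5-trimethoxyphenyl. None of the three measured steps touches this part of the structure; all of them concern the other end of the molecule. Among the measured compounds shown here, there is therefore no measured step to lean on, and the measured steps that exist, all within the scatter, give no sign that a small change moves the number far. The step from compound 3 to compound 4 is expected to be a 1.1-fold lower number from compound 3 to compound 4 (0.05 log units; within the scatter), nothing beyond the scatter. Compound 4 is accordingly estimated at 21000 nM, with a range from 8000 nM to 55000 nM.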

Compound 4, half-maximal inhibitory concentration: 19200 nM
Beside the measured number, compound 4's estimate is 1.1-fold (0.04 log units) above it; measured number inside the range.
By their numbers in this assay, from the lowest: compounds 1, 4, 2 and 3 (each within the scatter of the next).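

Putting methoxy in place of hydrogen, which turns 3,4-dimethoxyphenyl into 3,4,5-trimethoxyphenyl, gives in this assay a 1.2-fold lower number from compound 3 to compound 4 (0.08 log units; within the scatter), and this is the only step shown at this end of the molecule. Every earlier step concerned the other end, so this result adds a second site: on an aromatic carbon ortho to a methoxy group, this methoxy can take the place of hydrogen while the number stays within the scatter, which means the step cannot be told apart from no change at all. Nothing available here offers an explanation for this result.

As far as these compounds go, what a hydroxyl group, an amine or a carboxylic acid would do in this same place stays open, as does the effect of a longer chain such as propoxy. Also open, from the compounds shown here alone, is whether methoxy in place of hydrogen at this position would give a similar step on compound 1 or compound 2, which differ from compound 3 at the other end of the molecule.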